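A few compounds are considered here, and "the series" means these few. Any claim that something is new, unique, unknown or untested is made for them only; others in the source may bear on it.

Among the compounds with values here, compound 2 `CCC(C)NC(=C\C(=O)/C=C/c1ccc(O)cc1)/C=C/c1ccc(O)cc1` is one of two compounds measured in a functional assay for inhibition, read by spectrophotometry, with a stated time of 30 min, tested at 1 uM; on this read-out lower numbers stand for less inhibition and higher numbers for more inhibition at the one concentration tested (going by the name of the read-out); in this assay compound 2 gives 0.03%, and compound 1 `CC(C)CNC(=C\C(=O)/C=C/c1ccc(O)cc1)/C=C/c1ccc(O)cc1` gives 0.02%. Within the data shown here, the only step between them, a number 0 percentage points higher from compound 1 to compound 2 (within the scatter), is a swap of one alkyl group for another on the amine nitrogen. Compound 3 `O=C(/C=C(/C=C/c1ccc(O)cc1)NC1CCCCC1)/C=C/c1ccc(O)cc1` carries the next such change: cyclohexyl in place of sec-butyl on an amine nitrogen. Among the measured compounds shown here, since the one step of this kind stayed within the scatter, no step beyond the scatter is expected, and the expected step is a number 0.1 percentage points higher from compound 2 to compound 3 (within the scatter). Compound 3 is therefore estimated at 0.1%, between 0% and 8%.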

Compound 3, a percentage reported as inhibition, at one concentration (the size of the read-out at that concentration, not a potency): 0.03%
For compound 3 the middle estimate is 0.1 percentage points above the measured one; low and high end bracket the measured number.
By their numbers in this assay, from the lowest: compounds 1, 2 and 3 (each within the scatter of the next).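

In this assay, a six-membered non-aromatic ring of carbon on the amine nitrogen reads no differently from the open alkyl groups: the record shows no change at the digits printed from compound 2 to compound 3 (within the scatter), and a number 0 percentage points higher from compound 1 to compound 3 (within the scatter). Going from sec-butyl or isobutyl to cyclohexyl thus adds ring and size at this position without moving the number beyond the scatter. Nothing available explains this result.

All three compounds give very small numbers at the one concentration tested. As far as these compounds go, whether a benzyl group or a carboxylic acid on a longer chain at this nitrogen would give a larger number remains open.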